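The source may report more compounds than this note shows. Statements on the series, on what has been measured and on what is new or still open speak of the compounds shown alone.

Of the compounds shown here, three built on one shared core have been measured in an assay on a protein complex for inhibition of CDK8/Cyclin C (Homo sapiens), with a stated time of 1 h, tested at 10 uM; on this read-out lower numbers stand for less inhibition and higher numbers for more inhibition at the one concentration tested (going by the name of the read-out). Compound 1 `O=C(/C=C/c1ccncc1-c1ccc2[nH]ccc2c1)N1CCOCC1` gives 97%. Among the compounds with values here, compound 2 `CCOC(=O)/C=C/c1ccncc1-c1ccc2[nH]ccc2c1` gives 100%; the single change between them, a number 3 percentage points higher from compound 1 to compound 2 (within the scatter), is within the scatter. Within the data shown here, compound 3 `CNC(=O)/C=C/c1ccncc1-c1ccc2c(ccn2C)c1` gives 99%, the second highest of the three numbers, close to compound 2 and to compound 1, so that no compound in this group can be set apart from the others.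

Compound 4 `CNC(=O)/C=C/c1ccncc1-c1ccc2[nH]ccc2c1` differs from compound 3 in one place: hydrogen in place of methyl on an aromatic nitrogen. Among the measured compounds shown here, no measured pair differs only in this way, so no measured step bears on this change directly. What the data do show is that compound 1, which carries a hydrogen on that aromatic nitrogen, gives 97%, and compound 2, with the same hydrogen, gives 100%. The step of a number 1 percentage points lower from compound 3 to compound 4 (within the scatter) is therefore expected to stay within the scatter. Compound 4 is estimated to give 98%, with a range from 91% to 100%.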

Compound 4, a percentage reported as inhibition, at one concentration (the size of the read-out at that concentration, not a potency): 100%
Estimate against measurement, compound 4: 2 percentage points below, within the range that was stated.
By their numbers in this assay, from the lowest: compounds 1, 3, 2 and 4 (each within the scatter of the next).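

In this assay, within the data shown here, hydrogen in place of methyl on the aromatic nitrogen gives a number 1 percentage points higher from compound 3 to compound 4 (within the scatter); this is the first pair to test this position directly, and on this read-out the two groups cannot be told apart there. On the carbonyl carbon, methylamino in place of ethoxy gives no change at the digits printed from compound 2 to compound 4 (within the scatter), and methylamino in place of morpholin-4-yl gives a number 3 percentage points higher from compound 1 to compound 4 (within the scatter), so these three groups cannot be told apart either. Nothing available explains these results. As far as these compounds go, it remains open how a longer chain on the aromatic nitrogen, or a carboxylic acid on the carbonyl carbon, would read. With every compound read at a single concentration, any difference in potency among these four also stays open.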